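Bromo to methyl on the shared core

The source may hold more compounds than are shown below. What is called first, only, known or untested is meant among the compounds shown, and "the series" means these compounds.

In a functional assay on KB cells (Homo sapiens) for antiproliferative activity, read by colorimetric assay and MTT assay (a lower number here means a stronger inhibitor, a higher number a weaker inhibitor), compound 1 `Nc1ccc(S(=O)(=O)Nc2ccc(Cl)c3c(Cl)c[nH]c23)cc1` gives 14 ug/mL, compound 2 `Nc1ccc(S(=O)(=O)Nc2ccc(F)c3c(Cl)c[nH]c23)cc1` gives 14 ug/mL and compound 3 `Nc1ccc(S(=O)(=O)Nc2ccc(Br)c3c(Cl)c[nH]c23)cc1` gives 13 ug/mL. Compound 3 therefore stands within the scatter of both others. Compound 4 `Cc1ccc(NS(=O)(=O)c2ccc(N)cc2)c2[nH]cc(Cl)c12` differs from it by methyl in place of bromo on an aromatic carbon, para to a large group. The nearest evidence is the exchange of one halo group for another at this place: no change at the digits printed from compound 1 to compound 2 (within the scatter), a 1.1-fold lower number from compound 1 to compound 3 (0.03 log units; within the scatter) and a 1.1-fold lower number from compound 2 to compound 3 (0.03 log units; within the scatter), all within the scatter. Going by the values given here, no measured compound carries methyl here, so the evidence is indirect. The expected step is a 1.1-fold higher number from compound 3 to compound 4 (0.03 log units; within the scatter), with no change beyond the scatter in this assay. For compound 4 the estimated value is 14 ug/mL, with an expected range of 8 ug/mL to 25 ug/mL.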

Compound 4, half-maximal inhibitory concentration: 16 ug/mL
Beside the measured number, compound 4's estimate is 1.1-fold (0.06 log units) below it, within the range that was stated.
By their numbers in this assay, from the lowest: compounds 3, 1, 2 and 4 (each within the scatter of the next).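

In this assay, going by these compounds alone, methyl, the first group here that is not a halo group, gives no step beyond the scatter against bromo (a 1.2-fold higher number from compound 3 to compound 4 (0.09 log units; within the scatter)), fluoro (a 1.1-fold higher number from compound 2 to compound 4 (0.06 log units; within the scatter)) or chloro (a 1.1-fold higher number from compound 1 to compound 4 (0.06 log units; within the scatter)). The flat result at this place, para to a large group, therefore extends from the three halo groups to a carbon substituent. No measured evidence bearing on a cause accompanies these numbers.

As far as these compounds go, whether an amine, a carboxylic acid or a longer chain here would shift the number beyond the scatter stays open. So does whether any change at this place can do so.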